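Solubility across amide caps on the shared core

The compounds below may be only part of what the source reports. "The series", "measured", "known", "first", "only" and "open" are said of these compounds alone.

Compound 3 `O=C(C1CCCCC1)N1CCN(c2nc(=O)c3cc(C(F)(F)F)cc([N+](=O)[O-])c3s2)CC1` gives 3.24 ug/mL in a physicochemical assay for solubility, read by HPLC; on this read-out lower numbers stand for lower solubility and higher numbers for higher solubility. It sits among three numbers that all lie within the scatter of one another: nearest is compound 1 `O=C(c1ccccc1F)N1CCN(c2nc(=O)c3cc(C(F)(F)F)cc([N+](=O)[O-])c3s2)CC1` with 3.1 ug/mL, the step being a 1.0-fold higher number from compound 1 to compound 3 (0.02 log units; within the scatter); furthest is compound 2 `CC(C)(C)C(=O)N1CCN(c2nc(=O)c3cc(C(F)(F)F)cc([N+](=O)[O-])c3s2)CC1` with 5.87 ug/mL, and the steps there read a 1.8-fold lower number from compound 2 to compound 3 (0.26 log units; within the scatter) and a 1.9-fold higher number from compound 1 to compound 2 (0.28 log units; within the scatter). Compound 4 `O=C(c1ccc(F)cc1)N1CCN(c2nc(=O)c3cc(C(F)(F)F)cc([N+](=O)[O-])c3s2)CC1` carries 4-fluorophenyl in place of cyclohexyl on a carbonyl carbon. Going by the values given here, the one measured step that bears on it is the exchange of an aromatic cap for cyclohexyl, a 1.0-fold higher number from compound 1 to compound 3 (0.02 log units; within the scatter), which stayed within the scatter in this assay; no other step touches an aromatic cap. For compound 4 no step beyond the scatter is therefore expected: a 1.0-fold higher number from compound 3 to compound 4 (0.01 log units; within the scatter). Compound 4 is estimated at 3.3 ug/mL, within a range of 1.5 ug/mL to 7.5 ug/mL.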

Compound 4, solubility: 1.69 ug/mL
Beside the measured number, compound 4's estimate is 2.0-fold (0.29 log units) above it, and the stated range covers the measured number.
By their numbers in this assay, from the lowest: compounds 4, 1, 3 and 2 (each within the scatter of the next, the first and the last beyond it).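

In this assay this position now shows its first step beyond the scatter, with a 3.5-fold lower number from compound 2 to compound 4 (0.54 log units; beyond the scatter) when 4-fluorophenyl replaces tert-butyl on the carbonyl carbon. Against the other caps the change stays within the scatter, with a 1.9-fold lower number from compound 3 to compound 4 (0.28 log units; within the scatter) for the exchange from cyclohexyl and a 1.8-fold lower number from compound 1 to compound 4 (0.26 log units; within the scatter) for the exchange from 2-fluorophenyl, so only tert-butyl separates from 4-fluorophenyl. Nothing on hand gives a reason for this step.

Open, as far as these compounds go, is whether a cap bearing an amine or a carboxylic acid would move the number beyond the scatter from all four compounds.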